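The source may report more compounds than this note shows. Statements on the series, on what has been measured and on what is new or still open speak of the compounds shown alone.

Compound 1 `CCn1c(C(=O)NCCN(C)C)ccc1C(CC)(CC)c1ccc(OCC(=O)C(C)(C)C)c(C)c1` gives 77 nM in an assay on HL-60 cells for agonist activity at vitamin D3 receptor (Homo sapiens), read by microscopy, with a stated time of 96 h; on this read-out lower numbers stand for an effect already at smaller amounts and higher numbers for an effect only at larger amounts of compound.
Compound 2 `CCn1c(C(=O)N(CCC#N)CCC#N)ccc1C(CC)(CC)c1ccc(OCC(=O)C(C)(C)C)c(C)c1` gives 870 nM in this assay.

Compound 2 stands at the higher of these two numbers, with the step of an 11-fold higher number from compound 1 to compound 2 (1.05 log units; beyond the scatter) separating it from compound 1. Compound 3 `C#CCCOC(=O)c1ccc(C(CC)(CC)c2ccc(OCC(=O)C(C)(C)C)c(C)c2)n1CC` is not yet measured; it differs from compound 2 by a group of 5 heavy atoms (4 carbon, 1 oxygen; no ring) in place of a group of 9 heavy atoms (6 carbon, 3 nitrogen; no ring), on a carbonyl carbon. Within the data shown here, the only measured step at this same carbonyl carbon, an 11-fold higher number from compound 1 to compound 2 (1.05 log units; beyond the scatter), shows that exchanging the group there can move the number a great deal, but it gives no guide to the direction for an ester. A return toward the smaller compound 1 is expected, giving an estimated step of a 4.4-fold lower number from compound 2 to compound 3 (0.64 log units; beyond the scatter). Compound 3 is expected at 200 nM, between 40 nM and 1000 nM.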

Compound 3, half-maximal effective concentration: 28800 nM
For compound 3 the middle estimate is 140-fold (2.16 log units) below the measured one, and the stated range ends below it.
By their numbers in this assay, from the lowest: compound 1; then compound 2; then compound 3.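

On this carbonyl carbon, the ester carrying (but-3-yn-1-yl)oxy sits well behind both amides, with a 33-fold higher number from compound 2 to compound 3 (1.52 log units; beyond the scatter) and a 370-fold higher number from compound 1 to compound 3 (2.57 log units; beyond the scatter). The group here can therefore shift the number further than the earlier amide comparison showed. No measurement given here explains the shift. The compounds shown leave open whether the ester link or the but-3-yn-1-yl chain accounts for the higher number. A methyl ester, a carboxylic acid, or an amide bearing the same chain would help separate the two.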